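The source may report more compounds than this note shows. Statements on the series, on what has been measured and on what is new or still open speak of the compounds shown alone.

Measured in an assay on HEK293 cells for antagonist activity at P2X purinoceptor 7 (Homo sapiens), read by fluorescence, with a stated time of 2 h; on this read-out higher numbers stand for weaker inhibition and lower numbers for stronger inhibition:
compound 1, `CNC(=O)c1cccc(S(=O)(=O)Oc2ccc(-c3cncn3C3CCN(C(=O)c4ccc(Cl)c(C(F)(F)F)c4)CC3)cc2)c1`: 112 nM
compound 2, `CNC(=O)c1cccc(S(=O)(=O)Oc2ccc(-c3cncn3C3CCN(C(=O)c4ccc(OC)cc4)CC3)cc2)c1`: 159 nM

Among the measured compounds shown here, compound 2 is one of only two compounds with a number so far, and its sole neighbour is compound 1. For the measured compounds named here, the single measured step, a 1.4-fold higher number from compound 1 to compound 2 (0.15 log units; within the scatter), lies within the scatter, so the two values cannot be told apart and neither compound can be called stronger or weaker.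

Compound 3, `COc1ccc(C(=O)N2CCC(n3cncc3-c3ccc(OS(=O)(=O)c4cccc(C(=O)NC5CC5)c4)cc3)CC2)cc1`, differs from compound 2 by cyclopropyl in place of methyl on an amide-type nitrogen whose other neighbour is a carbonyl carbon. Going by the values given here, no measured step touches this amide-type nitrogen. Among the compounds with values here, the one step available, a 1.4-fold higher number from compound 1 to compound 2 (0.15 log units; within the scatter), concerns the group on a carbonyl carbon and was within the scatter; it therefore bears on the present change only indirectly, by showing that one small swap left this assay essentially unchanged.

With nothing pointing either way, compound 3 is expected to stay close to compound 2, so the expected step is a 1.1-fold lower number from compound 2 to compound 3 (0.03 log units; within the scatter), not beyond the scatter. The estimate for compound 3 is 150 nM, in a range from 55 nM to 420 nM.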

Compound 3, half-maximal inhibitory concentration: 244 nM
Compound 3: the middle estimate sits 1.6-fold (0.21 log units) below what was measured, within the range that was stated.
By their numbers in this assay, from the lowest: compounds 1, 2 and 3 (each within the scatter of the next, the first and the last beyond it).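

In this assay, the amide-type nitrogen now has a measured step of its own: cyclopropyl in place of methyl gives a 1.5-fold higher number from compound 2 to compound 3 (0.19 log units; within the scatter), so compound 2 and compound 3 cannot be told apart. The group on this nitrogen grows from 1 heavy atom to 3 heavy atoms and gains a three-membered ring, yet the difference stays inside what repeat measurements of this kind would be expected to show, which means that, of these two groups, this read-out does not favour either one. Nothing measured here speaks to the reason for this result.

Going by these compounds, what a longer chain such as n-butyl, or a group carrying an amine or a carboxylic acid, would do on this same nitrogen remains open, so the two groups compared here give no view of how much wider a range of groups the position can take. On these data alone, it is also open whether cyclopropyl would behave the same way with the 4-chloro-3-(trifluoromethyl)phenyl group of compound 1 on the carbonyl carbon at the other end of the molecule.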